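Amide nitrogen substitution on the shared core: compound 3 to 4

A few compounds are considered here, and "the series" means these few. Any claim that something is new, unique, unknown or untested is made for them only; others in the source may bear on it.

Measured compounds:
compound 1 `CC[C@H]1CN(c2nc(N)c(C(=O)NCCNS(N)(=O)=O)nc2Cl)CCN1C1CCN(Cc2ccc(Cl)cc2)CC1`: in an in vitro assay on BaF3 cells for displacement of a labelled ligand from C-X-C chemokine receptor type 3 (Homo sapiens) (a lower number here means a stronger inhibitor, a higher number a weaker inhibitor), compound 1 gives 1.9 nM
compound 2 `CC[C@H]1CN(c2nc(N)c(C(=O)NCCNS(C)(=O)=O)nc2Cl)CCN1C1CCN(Cc2ccc(Cl)cc2)CC1`: in this assay compound 2 gives 4.4 nM
compound 3 `CC[C@H]1CN(c2ncc(C(N)=O)nc2Cl)CCN1C1CCN(C(=O)c2ccc(Cl)nc2N)CC1`: in this assay compound 3 gives 2.5 nM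

Compound 3 stands second highest of the three numbers, and its gaps to compound 1 and to compound 2 both lie within the scatter. Compound 4 `CC[C@H]1CN(c2ncc(C(=O)NCCO)nc2Cl)CCN1C1CCN(C(=O)c2ccc(Cl)nc2N)CC1` differs from compound 3 by 2-hydroxyethyl in place of hydrogen on an amide-type nitrogen. Among the measured compounds shown here, the only measured step, a 2.3-fold higher number from compound 1 to compound 2 (0.36 log units; beyond the scatter), alters a group on a sulfonyl sulfur and leaves the amide nitrogen untouched, so it does not bear on this change. Compound 1 and compound 2 carry a substituted amide nitrogen, but each differs from compound 3 in more than one place, so only their two values can be set beside it, and they sit close to compound 3. No step beyond the scatter is therefore expected in this assay. Compound 4 is expected at 2.5 nM, within 1 nM to 6 nM. The expected step of no change at the digits printed from compound 3 to compound 4 (within the scatter) stays within the scatter.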

Compound 4, half-maximal inhibitory concentration: 2.9 nM
Estimate against measurement, compound 4: 1.2-fold (0.06 log units) below, within the range that was stated.
By their numbers in this assay, from the lowest: compounds 1, 3, 4 and 2 (each within the scatter of the next, the first and the last beyond it).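

In this assay, among the compounds shown here, putting 2-hydroxyethyl in place of hydrogen on the amide-type nitrogen gives a 1.2-fold higher number from compound 3 to compound 4 (0.06 log units; within the scatter), the first single-change reading at this position. On this core, carbamoyl and (2-hydroxyethyl)carbamoyl therefore cannot be told apart in this assay. No measurement shown here offers an explanation for this result.

On these data alone, whether a longer chain on this nitrogen, or a chain ending in an amine or a carboxylic acid, would also stay within the scatter of compound 3 remains open. So does whether a single substituent this small says anything about larger groups here.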